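This account rests on a few compounds, and the source may have more. Where it says the series, first, only, none or still open, it means among the compounds named here.

Working notes on the series. Compound 1 `COc1ccc(-c2nc(SCC(=O)c3sc(-c4ccccc4)nc3C)[nH]c(=O)c2C#N)cc1` gives 1.08% in a functional assay on U-87MG ATCC cells for antiproliferative activity against U-87 MG (Homo sapiens), read by MTT assay, with a stated time of 48 h, tested at 100 uM; a lower number here means a stronger effect, a higher number a weaker effect of the compound at the concentration tested. Compound 2 `Cc1nc(-c2ccccc2)sc1C(=O)CSc1nc(-c2cccc(Cl)c2)c(C#N)c(=O)[nH]1` gives 10% in this assay. For the measured compounds named here, the one step between them, a number 8.9 percentage points higher from compound 1 to compound 2 (within the scatter), is the only measured step in the set. Going by the values given here, on the numbers so far compound 2 carries the higher of the two figures, but its gap to compound 1 is within the scatter, so no order between the two can be read.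

The next compound, compound 3 `Cc1nc(-c2ccccc2)sc1C(=O)CSc1nc(-c2ccccc2)c(C#N)c(=O)[nH]1`, differs from compound 2 by hydrogen in place of chloro on an aromatic carbon. Among the compounds with values here, no measured step removes a chloro, so nothing bears on this change directly. Within the data shown here, the only step at hand, a number 8.9 percentage points higher from compound 1 to compound 2 (within the scatter), exchanged one substituted phenyl for another and stayed within the scatter, which gives no sign that the group on that phenyl drives the read-out in this assay. The expected step from compound 2 to compound 3 in this assay is therefore a number 3 percentage points lower from compound 2 to compound 3 (within the scatter), small and not beyond the scatter. For compound 3 the estimate in this assay is 7%, expected to lie between -5% and 25%.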

Compound 3, a percentage reported as activity, at one concentration (the size of the read-out at that concentration, not a potency): 9.23%
Compound 3: the middle estimate sits 2.2 percentage points below what was measured; low and high end bracket the measured number.
By their numbers in this assay, from the lowest: compounds 1, 3 and 2 (each within the scatter of the next).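

Removing the chloro gives the unsubstituted phenyl as a reference point for this position. In this assay the step reads a number 0.8 percentage points lower from compound 2 to compound 3 (within the scatter) and shows no separation between 3-chlorophenyl and phenyl, while the comparison with the methoxy-bearing compound reads a number 8.2 percentage points higher from compound 1 to compound 3 (within the scatter) and shows none for that group either. Set against plain hydrogen, neither chloro nor methoxy on this phenyl has a readable effect here, so compounds 1, 2 and 3 stand as one group without an order, and nothing at hand accounts for this result.

From the compounds shown here alone, whether an amine or a carboxylic acid on this phenyl would move the read-out beyond the scatter stays open, as does the effect of any change away from this phenyl, such as replacing the nitrile on the shared core with an amide. All three figures come from a single concentration, so they give no potency and leave open whether the compounds would differ at lower concentrations.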